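Sulfamoylamino piperidines: swapping butyl for chloro

The source may report more compounds than this note shows. Statements on the series, on what has been measured and on what is new or still open speak of the compounds shown alone.

Measured so far, all in a functional assay on M21 cells (Homo sapiens) for antiproliferative activity, read by sulforhodamine B assay, with a stated time of 48 h; on this read-out lower numbers stand for stronger inhibition of growth and higher numbers for weaker inhibition of growth:
compound 1 `CCCCc1ccc(-c2cc(N3CCC(CNS(N)(=O)=O)CC3)ncn2)cc1`: 47200 nM
compound 2 `NS(=O)(=O)NCC1CCN(c2cc(-c3ccc(Cl)cc3)ncn2)CC1`: 50300 nM
compound 3 `CCCCc1ccc(-c2cc(N3CCC(CCNS(N)(=O)=O)CC3)ncn2)cc1`: 15100 nM

Compound 3 holds the lowest number of the three in this assay; compound 1 sits at a 3.1-fold lower number from compound 1 to compound 3 (0.49 log units; beyond the scatter) and compound 2 a little further off, both beyond the scatter. Compound 4 `NS(=O)(=O)NCCC1CCN(c2cc(-c3ccc(Cl)cc3)ncn2)CC1` is not yet measured. It differs from compound 3 by chloro in place of butyl on an aromatic carbon, the same replacement that separates compound 1 from compound 2, where it gave a 1.1-fold higher number from compound 1 to compound 2 (0.03 log units; within the scatter). Going by the values given here, that earlier step is the only direct precedent, and it lies within the scatter. The step from compound 3 to compound 4 is therefore expected to be of the same kind: a 1.1-fold higher number from compound 3 to compound 4 (0.03 log units; within the scatter), no change beyond the scatter, in this assay. On that basis compound 4 is estimated at 16000 nM in this assay, with a range of 6000 nM to 45000 nM; a single precedent gives only limited confidence, so the range is kept wide.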

Compound 4, concentration for 50% growth inhibition: 45200 nM
The estimate for compound 4 lay 2.8-fold (0.45 log units) below the measured number; the measured number lies above the stated range.
By their numbers in this assay, from the lowest: compound 3; then compounds 4, 1 and 2 (each within the scatter of the next).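

In this assay, chloro in place of butyl on an aromatic carbon is not a silent change on every core: a 3.0-fold higher number from compound 3 to compound 4 (0.48 log units; beyond the scatter) shows that the result on the shorter side chain does not carry over, and the two cores disagree: the same change on two cores in this assay, a 1.1-fold higher number (0.03 log units; within the scatter) from compound 1 to compound 2 and a 3.0-fold higher number (0.48 log units; beyond the scatter) from compound 3 to compound 4, 2.8-fold (0.45 log units) apart, beyond the scatter of two such steps. The side-chain change likewise depends on the aromatic group, as with chloro in place of butyl it gives only a 1.1-fold lower number from compound 2 to compound 4 (0.05 log units; within the scatter), and the two steps differ: the same change on two cores in this assay, a 3.1-fold lower number (0.49 log units; beyond the scatter) from compound 1 to compound 3 and a 1.1-fold lower number (0.05 log units; within the scatter) from compound 2 to compound 4, 2.8-fold (0.45 log units) apart, beyond the scatter of two such steps. The two changes therefore do not add independently in these four compounds, and the lowest number, that of compound 3, appears only where butyl and the longer side chain occur together.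

Still open, going by these compounds, is whether an ethyl or methoxy group on that aromatic carbon follows butyl or chloro on the longer side chain. Also open, on these data alone, is whether a longer chain, or an amine or carboxylic acid in place of the sulfamoylamino group, keeps this dependence.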